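A few compounds are considered here, and "the series" means these few. Any claim that something is new, unique, unknown or untested is made for them only; others in the source may bear on it.

Three compounds with a phenyl-terminated chain on a shared core have been tested in a functional assay on NCI-H630 cells (Homo sapiens) for cytotoxicity, read by sulforhodamine B assay, with a stated time of 5 days; on this read-out higher numbers stand for weaker inhibition and lower numbers for stronger inhibition. There, compound 1 (`O=C(CCCCCCc1ccccc1)CC(=O)N[C@H]1CCOC1=O`) gives 65000 nM and compound 2 (`O=C(CCCCCCCCCCc1ccccc1)CC(=O)N[C@H]1CCOC1=O`) gives 23000 nM. Compound 3 (`O=C(CCCCCCCCCc1ccccc1)CC(=O)N[C@@H]1CCOC1=O`) gives > 100000 nM in this assay, and this is a limit of the assay, not a number. Compound 3 therefore has no exact position on the scale.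

Compound 4 (`O=C(CCCCCCCCCc1ccccc1)CC(=O)N[C@H]1CCOC1=O`) has not yet been measured. Its relation to compound 3 is a change of configuration alone: the two compounds have the same atoms and bonds and differ only in configuration as drawn: 1 of 1 stereo elements differ; a stereocentre at a saturated ring carbon is drawn R in compound 3 and S in compound 4. The ring stereocentre of compound 4 is drawn as in compound 1 and compound 2, whose chains are shorter and longer than its own. Both of those compounds give numerical values, so compound 4 is expected to give one too, with stronger inhibition than the limit of compound 3. The expected change is an at least 3.1-fold lower number from compound 3 to compound 4 (0.49 log units; beyond the scatter), a step clearly beyond the scatter. For compound 4 the estimated value is 32000 nM, with an expected range from 13000 nM to 80000 nM.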

Compound 4, half-maximal inhibitory concentration: 16000 nM
Beside the measured number, compound 4's estimate is 2.0-fold (0.30 log units) above it; measured number inside the range.
By their numbers in this assay, from the lowest: compounds 4 and 2 (each within the scatter of the next); then compound 1. At a limit, above all of these: compound 3.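

In this assay there is an at least 6.2-fold lower number from compound 3 to compound 4 (0.79 log units; beyond the scatter), and this step can be laid on the ring stereocentre alone: the fact that compounds 3 and 4 differ only in the configuration as drawn Compound 3 gives > 100000 nM, which is a limit and not a number, so the step gives only a bound on the size of the change: the limit of > 100000 nM in this assay, at which 1 of the 4 values shown sits. With the stereocentre drawn S throughout, the chain now reads in part, with a 4.1-fold lower number from compound 1 to compound 4 (0.61 log units; beyond the scatter), yet a 1.4-fold lower number from compound 2 to compound 4 (0.16 log units; within the scatter), so the last chain step shows no change that can be read.

Only one chain is shown in both configurations, so whether the stereocentre step holds at other chain lengths stays open. Also open, as far as these compounds go, is how a chain ending in a carboxylic acid or an amine in place of phenyl would read in this assay.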